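The source may hold more compounds than are shown below. What is called first, only, known or untested is meant among the compounds shown, and "the series" means these compounds.

Measured in a functional assay on LoVo cells (Homo sapiens) for cytotoxicity, read by colorimetric assay and MTT assay; on this read-out higher numbers stand for weaker inhibition and lower numbers for stronger inhibition:
- compound 1 `COc1cccc2cc(-c3ccccc3)c(O)nc12`: 10000 nM
- compound 2 `COc1ccc(-c2cc3cccc(OC)c3nc2O)cc1`: 10000 nM
- compound 3 `COc1ccc(-c2cc3c(OC)cc(OC)cc3n(CC#N)c2=O)cc1`: 10000 nM

Compounds 1 and 2 stand level with compound 3, and at 10000 nM compound 3 offers no separation from either of them. The next compound, compound 4 `COc1ccc(-c2cc3c(OC)cc(OC)cc3n(CCC#N)c2=O)cc1`, carries cyanomethyl in place of cyano on a saturated chain carbon bound to an aromatic nitrogen, which lengthens the cyanomethyl substituent of compound 3 to 2-cyanoethyl (cyanomethyl in place of cyano on a saturated chain carbon bound to an aromatic nitrogen).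

For the measured compounds named here, only one measured step is available, and it bears on this change only indirectly. The step of no change at the digits printed from compound 1 to compound 2 (within the scatter) is methoxy in place of hydrogen on an aromatic carbon, stayed within the scatter, and involves a different kind of change. Going by the values given here, no measured pair tests the chain on the aromatic nitrogen. In this assay, therefore, no step beyond the scatter is expected, and no direction can be favoured with confidence, though the range is left open towards stronger inhibition.

The expected step is no change at the digits printed from compound 3 to compound 4 (within the scatter).

Compound 4 is estimated at 10000 nM, within an expected range of 3000 nM to 10000 nM.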

Compound 4, half-maximal inhibitory concentration: 10000 nM
Estimate against measurement, compound 4: no gap at the digits printed; the range from low to high includes it.
By their numbers in this assay, from the lowest: compounds 1, 2, 3 and 4 (each within the scatter of the next).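

For the compounds shown here, the change of cyanomethyl to 2-cyanoethyl on the aromatic nitrogen gives the first measured reading of that chain in this assay, with no change at the digits printed from compound 3 to compound 4 (within the scatter) as its outcome. Going by these compounds alone, the earlier step concerned methoxy on an aromatic carbon, so only this pair shows that the added chain length alone does not separate two compounds on the shared core, with compound 4 at 10000 nM. No evidence accompanies this result that could speak to its cause.

On these data alone, whether an amine, a carboxylic acid or a longer chain in place of cyanomethyl would shift the read-out in this assay remains open. With compounds 1, 2, 3 and 4 all level, the compounds shown include no change that moves the value beyond the scatter.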